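The source may report more compounds than this note shows. Statements on the series, on what has been measured and on what is new or still open speak of the compounds shown alone.

Measured compounds:
- compound 1, `Brc1ccc(N2CCNCC2)cn1`: in an assay on HEK293 cells with Neuronal acetylcholine receptor; alpha4/beta2 (Homo sapiens) as the target, read by FLIPR and calcium flux (on this read-out lower numbers stand for smaller maximal responses and higher numbers for larger maximal responses), compound 1 gives 129%
- compound 2, `C=COc1cc(N2CCCNCC2)cnc1Br`: in this assay compound 2 gives 80%

Of these two numbers, compound 2 holds the lower one; compound 1 stands higher by an amount beyond the usual scatter, so the two readings differ in fact and not merely by chance. Within the data shown here, no pair of measured compounds differs in a single place, so there is no measured guide to what one small exchange does in this assay.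

Compound 3, `C=COc1cncc(N2CCCNCC2)c1`, is the next compound, still unmeasured in this assay. Set against compound 2 it differs in one place only: hydrogen in place of bromo on an aromatic carbon. The bromo leaves and a hydrogen takes its place on an aromatic carbon of the six-membered aromatic ring with 1 nitrogen; the vinyloxy group and the group of 7 heavy atoms remain as they are.

Without a measured step of this kind to lean on, the expectation for compound 3 is a step of a number 5 percentage points lower from compound 2 to compound 3 (within the scatter) that stays small, in no settled direction, and probably not beyond the scatter. Compound 3 is accordingly estimated at 75%, within a range from 45% to 115%.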

Compound 3, largest response reached (reported as efficacy), in percent of the reference or control that the assay uses: 61%
Beside the measured number, compound 3's estimate is 14 percentage points above it; the measured number falls inside the stated range.
By their numbers in this assay, from the lowest: compound 3; then compound 2; then compound 1.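

In this assay, among these compounds, the exchange of bromo for hydrogen on the aromatic carbon next to the ring nitrogen and ortho to a vinyloxy group gives a number 19 percentage points lower from compound 2 to compound 3 (beyond the scatter), the first measured step here between compounds that differ in one place. This shows that the position is not indifferent to what sits on it: the modest drop lies beyond the usual scatter, and compound 2, with the bromo, reaches the larger maximal response of the pair. The data shown offer no evidence on why this exchange lowers the response.

The compounds shown leave open whether the response at this carbon follows the size of the group or something else, and whether a chloro, a methyl or an amine there would give a number nearer to that of compound 2 or to that of compound 3. They also leave open whether the same exchange would give a step of similar size on a compound without the vinyloxy group, since compound 1 differs from compound 2 in more than one place and its higher number cannot be divided among those differences.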